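Changing the Other Aryl Group of Compound 3

A few compounds are considered here, and "the series" means these few. Any claim that something is new, unique, unknown or untested is made for them only; others in the source may bear on it.

In a functional assay on DU-145 cells (Homo sapiens) for inhibition, read by trypan blue exclusion, with a stated time of 96 h (a lower number here means a stronger inhibitor of growth, a higher number a weaker inhibitor of growth), compound 1 `O=C(/C(=C\c1ccc([N+](=O)[O-])c(O)c1)SCc1ccc(Br)cc1)c1ccc([N+](=O)[O-])c(Cl)c1` gives 1000 nM and compound 2 `O=C(/C(=C\c1ccc([N+](=O)[O-])c(O)c1)SCc1ccc(Br)cc1)c1ccc(C(F)(F)F)cc1` gives 1000 nM, with no change at the digits printed from compound 1 to compound 2 (within the scatter). Compound 3 `O=C(O)c1ccc(C(=O)/C(=C\c2ccc([N+](=O)[O-])c(O)c2)SCc2ccc(Br)cc2)cc1` has the highest number of the three, at 10000 nM, which makes it the weakest inhibitor of this small set. The steps leading to it are a 10-fold higher number from compound 1 to compound 3 (1.00 log units; beyond the scatter) and a 10-fold higher number from compound 2 to compound 3 (1.00 log units; beyond the scatter).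

Compound 4 `O=C(O)c1ccc(C(=O)/C(=C\c2ccc(Cl)c([N+](=O)[O-])c2)SCc2ccc(Br)cc2)cc1` keeps the carboxy group of compound 3 but has 4-chloro-3-nitrophenyl in place of 3-hydroxy-4-nitrophenyl on a double-bonded chain carbon bound to a double-bonded chain carbon.

All three measured steps changed the group on the carbonyl carbon, so none of them tests this other place, and their size cannot simply be carried over. Going by the values given here, the only anchor is compound 3 at 10000 nM, and no step beyond the scatter is expected in this assay. The expected outcome is no change at the digits printed from compound 3 to compound 4 (within the scatter). Compound 4 is estimated at 10000 nM, with a wide expected range of 3000 nM to 30000 nM.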

Compound 4, concentration for 50% growth inhibition: 500 nM
Estimate against measurement, compound 4: 20-fold (1.30 log units) above, and the stated range ends above it.
By their numbers in this assay, from the lowest: compounds 4, 1 and 2 (each within the scatter of the next); then compound 3.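

Going by these compounds alone, the earlier steps all changed the group on the carbonyl carbon, so this is the first look at the other aryl group, and in this assay replacing 3-hydroxy-4-nitrophenyl with 4-chloro-3-nitrophenyl gives a 20-fold lower number from compound 3 to compound 4 (1.30 log units; beyond the scatter). This position therefore affects the read-out, and a compound that keeps the carboxy group can still reach a much lower number. The step replaces hydroxy with chlorine and also relocates the nitro group, and nothing available here explains the drop in the number.

Which of these two differences accounts for the step remains open, and a phenyl group carrying only a nitro group or only a chlorine would help to separate them. Going by these compounds, it is also open whether an amine in place of the chlorine would give a similar number.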